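The source may report more compounds than this note shows. Statements on the series, on what has been measured and on what is new or still open speak of the compounds shown alone.

Measured in a functional assay on the whole organism (strain Kunming) with Mus musculus as the target, with a stated time of 0.5 h; on this read-out higher numbers stand for an effect only at larger amounts of compound and lower numbers for an effect already at smaller amounts:
- compound 1 `COc1ccccc1/C=C/C(=O)OC/C=C/c1cc(OC)c(OC)cc1OC`: 780 umol/kg
- compound 2 `COc1cc(OC)c(OC)cc1/C=C/COC(=O)/C=C/c1ccc(Br)cc1`: > 692 umol/kg (a limit, not a number)
- compound 3 `COc1cc(OC)c(OC)cc1/C=C/COC(=O)/C=C/c1cccc(Br)c1`: 497 umol/kg

For the measured compounds named here, compound 1 has only one neighbour with a true number, and the two lie within the usual scatter of each other: a 1.6-fold lower number from compound 1 to compound 3 (0.20 log units; within the scatter). Compound 4 `COc1cc(OC)c(OC)cc1/C=C/COC(=O)/C=C/c1ccc(F)cc1` differs from compound 1 by one swap, (4-fluorophenyl in place of 2-methoxyphenyl on a double-bonded chain carbon bound to a double-bonded chain carbon). Two measured swaps of the same 2-methoxyphenyl group bear on it. The 3-bromophenyl swap gave a 1.6-fold lower number from compound 1 to compound 3 (0.20 log units; within the scatter). The 4-bromophenyl swap gave a step that the limit leaves unreadable from compound 1 to compound 2. Neither shows a step beyond the scatter, so none is expected here. The estimated step is a 1.2-fold lower number from compound 1 to compound 4 (0.08 log units; within the scatter). For compound 4 the expected value is 650 umol/kg, within an estimated range from 330 umol/kg to 1200 umol/kg.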

Compound 4, dose for half-maximal effect: > 805 umol/kg
Compound 4 gave a limit, no number; the forecaster's own chance of this, stated with the estimate: 25%; middle value at least 1.2-fold (0.09 log units) from the limit.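

In this assay compound 4 gives > 805 umol/kg, which is a limit and not a number. The readable steps are an at least 1.0-fold higher number from compound 1 to compound 4 (0.01 log units; that floor lies within the scatter) and an at least 1.6-fold higher number from compound 3 to compound 4 (0.20 log units; that floor lies within the scatter), so 4-fluorophenyl at this place is not yet separated from 2-methoxyphenyl or 3-bromophenyl, and the steps that rest on two limits cannot be read. Compound 2 and compound 4, the two 4-halophenyl compounds, both end in limits, while compound 1 and compound 3 give true numbers. Still open, on these data alone, is whether any swap here gives a step beyond the scatter, and how an amine or a carboxylic acid on this phenyl ring would read.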